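A Benzyl Group Replaces a Phenyl on the Amide Nitrogen

The compounds below may be only part of what the source reports. "The series", "measured", "known", "first", "only" and "open" are said of these compounds alone.

Of the compounds shown here, three with a shared core have been measured in a functional assay on Huh-7 cells (Homo sapiens) for inhibition, read by MTT assay, with a stated time of 48 h (a higher number here means a weaker inhibitor, a lower number a stronger inhibitor), and their numbers nearly coincide. Compound 1 `COc1ccc2c(=O)c(/C=C/C(=O)Nc3ccccc3OC)coc2c1` gives 32300 nM with 2-methoxyphenyl on an amide-type nitrogen. Compound 2 `COc1ccc2c(=O)c(/C=C/C(=O)Nc3ccc(Cl)cc3)coc2c1` gives 37100 nM with 4-chlorophenyl in that place. Compound 3 `COc1ccc2c(=O)c(/C=C/C(=O)Nc3ccc(F)cc3)coc2c1` gives 33900 nM with 4-fluorophenyl and stands within the scatter of both others.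

Compound 4 `COc1ccc2c(=O)c(/C=C/C(=O)NCc3ccc(F)cc3F)coc2c1` has not yet been measured. It carries 2,4-difluorobenzyl in place of 4-fluorophenyl on an amide-type nitrogen and keeps the shared core.

Going by the values given here, three measured steps bear on this change. Replacing the 2-methoxyphenyl gave a 1.1-fold higher number from compound 1 to compound 2 (0.06 log units; within the scatter) with 4-chlorophenyl and a 1.0-fold higher number from compound 1 to compound 3 (0.02 log units; within the scatter) with 4-fluorophenyl. Fluoro in place of chloro gave a 1.1-fold lower number from compound 2 to compound 3 (0.04 log units; within the scatter) as well. All three are small, yet none of them introduces a benzyl group, so they are only an indirect guide. On that evidence, no change beyond the scatter is expected in this assay and the estimated step is a 1.1-fold lower number from compound 3 to compound 4 (0.05 log units; within the scatter) in size. Among the compounds with values here, no measured compound carries a benzyl group and the range therefore stays wide. For compound 4 the expected value is 30000 nM with an estimated range from 12000 nM to 70000 nM in all.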

Compound 4, half-maximal inhibitory concentration: > 100000 nM
Compound 4 was reported as a limit (the forecaster's own chance of this, stated with the estimate: 10%); at least 3.3-fold (0.52 log units) between middle value and limit.
By their numbers in this assay, from the lowest: compounds 1, 3 and 2 (each within the scatter of the next). At a limit, above all of these: compound 4.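

In this assay compound 4 is reported only as a limit of the assay: the limit of > 100000 nM in this assay, at which 1 of the 4 values shown sits.

On an amide-type nitrogen, 2,4-difluorobenzyl gives an at least 2.9-fold higher number from compound 3 to compound 4 (0.46 log units; beyond the scatter) when it replaces 4-fluorophenyl, an at least 2.6-fold higher number from compound 2 to compound 4 (0.43 log units; beyond the scatter) when it replaces 4-chlorophenyl and an at least 3.0-fold higher number from compound 1 to compound 4 (0.49 log units; beyond the scatter) when it replaces 2-methoxyphenyl. Going by these compounds alone, the three phenyl groups measured earlier sat within the scatter of one another, so they gave no sign that this position could matter, whereas this change is the first here to move the number beyond the scatter, towards a weaker inhibitor.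

The new group differs from the phenyl groups in two ways, with a further carbon in the benzyl group and a second fluorine on the ring, and the compounds shown do not separate these two changes. Also open, from the compounds shown here alone, is how a 4-fluorobenzyl group, an unsubstituted benzyl group, a longer chain such as 2-phenylethyl or a chain ending in an amine would read on this nitrogen, and how much weaker compound 4 really is than the limit alone can tell.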